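Changing the benzimidazolyl group of compound 3

The source may hold more compounds than are shown below. What is called first, only, known or untested is meant among the compounds shown, and "the series" means these compounds.

Three compounds sharing one core, differing in the amine chain, were tested in an ADME assay on HEK293 cells (Homo sapiens) for cytotoxicity, read by MTT assay, with a stated time of 48 h; on this read-out lower numbers stand for stronger inhibition and higher numbers for weaker inhibition. Compound 1 `CN(C)CCn1c(N)c(-c2nc3ccccc3n2C)c2nc(C#N)c(C#N)nc21` gives > 50000 nM, which is a limit of the assay and not a number. Compound 2 `CN(C)CCCn1c(N)c(-c2nc3ccccc3n2C)c2nc(C#N)c(C#N)nc21` reads 8410 nM, and compound 3 `CCN(CC)CCCCn1c(N)c(-c2nc3ccccc3n2C)c2nc(C#N)c(C#N)nc21` reads 3160 nM, the lower of the two true numbers. Along the chain, the measured steps are an at least 5.9-fold lower number from compound 1 to compound 2 (0.77 log units; beyond the scatter), an at least 15-fold lower number from compound 1 to compound 3 (1.19 log units; beyond the scatter) and a 2.7-fold lower number from compound 2 to compound 3 (0.43 log units; beyond the scatter).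

Compound 4 `CCN(CC)CCCCn1c(N)c(-c2nc3cc(Cl)ccc3[nH]2)c2nc(C#N)c(C#N)nc21` keeps the 4-(diethylamino)butyl group of compound 3 and changes another part: 5-chloro-1H-benzimidazol-2-yl in place of 1-methyl-1H-benzimidazol-2-yl on an aromatic carbon. Going by the values given here, all three measured steps lie on the chain, so none of them bears directly on this swap, and no measured compound carries the new group. The only anchor in this assay is therefore compound 3 at 3160 nM, and no step beyond the scatter is expected, though with wide uncertainty. The estimated change is a 1.1-fold lower number from compound 3 to compound 4 (0.02 log units; within the scatter). Compound 4 is expected at about 3000 nM, with an estimated range of 1000 nM to 10000 nM.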

Compound 4, half-maximal inhibitory concentration: 3860 nM
Estimate against measurement, compound 4: 1.3-fold (0.11 log units) below; low and high end bracket the measured number.
By their numbers in this assay, from the lowest: compounds 3 and 4 (each within the scatter of the next); then compound 2. At a limit, above all of these: compound 1.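

In this assay, the swap at this position shows up only as a 1.2-fold higher number from compound 3 to compound 4 (0.09 log units; within the scatter) and so leaves the read-out where it was. Going by these compounds alone, this is the first change away from the amine chain, and it shows that on the 4-(diethylamino)butyl compounds this aromatic carbon accepts 5-chloro-1H-benzimidazol-2-yl, with its chlorine and its hydrogen-bond donor, in place of 1-methyl-1H-benzimidazol-2-yl without a step beyond the scatter. Nothing measured here offers a reason for this flat result.

On these data alone, the swap removes the methyl and adds the chlorine in one move, so the share of each stays open, as does the possibility that their contributions cancel. The plain 1H-benzimidazol-2-yl group and 5-chloro-1-methyl-1H-benzimidazol-2-yl on the same chain would separate the two.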